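Removing the aromatic hydroxy of compound 3

The compounds below may be only part of what the source reports. "The series", "measured", "known", "first", "only" and "open" are said of these compounds alone.

Among the measured compounds shown here, compound 3 `COc1ccc(C2CC(=O)N2c2cc(OC)c(OC)c(OC)c2)cc1O` gives 8 nM in a functional assay on HL-60 cells (Homo sapiens) for inhibition, read by resazurin assay, with a stated time of 72 h (a lower number here means a stronger inhibitor, a higher number a weaker inhibitor), the lowest of the three numbers so far. For the measured compounds named here, compound 1 `C=CC1C(=O)N(c2cc(OC)c(OC)c(OC)c2)C1c1ccc(OC)cc1` gives 33 nM and compound 2 `COc1ccc(C2C(C3CC3)C(=O)N2c2cc(OC)c(OC)c(OC)c2)cc1` gives 156 nM; the one measured step, a 4.7-fold higher number from compound 1 to compound 2 (0.67 log units; beyond the scatter), concerns a saturated ring carbon and has no bearing on the aromatic position changed here. Compound 4 `COc1ccc(C2CC(=O)N2c2cc(OC)c(OC)c(OC)c2)cc1` differs from compound 3 by hydrogen in place of hydroxy on an aromatic carbon. Going by the values given here, no measured pair shows the loss of a hydroxy group, so the size of this step is unsupported by prior steps, and compound 3 standing lowest is the only guide. The expected outcome for compound 4 is a step of a 2.0-fold higher number from compound 3 to compound 4 (0.30 log units; within the scatter) in this assay, a modest weakening at most. Compound 4 is therefore estimated at 16 nM, within 5 nM to 50 nM.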

Compound 4, half-maximal inhibitory concentration: 76 nM
Estimate against measurement, compound 4: 4.8-fold (0.68 log units) below; the whole stated range lies below it.
By their numbers in this assay, from the lowest: compound 3; then compound 1; then compound 4; then compound 2.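

In this assay, the hydroxy on the aromatic carbon carries the largest step in the set (a 9.5-fold higher number from compound 3 to compound 4 (0.98 log units; beyond the scatter)). Compound 4 also gives a reference with hydrogen on the saturated ring carbon, and the two groups there part in direction: vinyl gives the lower number (a 2.3-fold higher number from compound 1 to compound 4 (0.36 log units; beyond the scatter)), cyclopropyl the higher (a 2.1-fold lower number from compound 2 to compound 4 (0.31 log units; beyond the scatter)). Nothing available bears on the reason for the hydroxy step.

As far as these compounds go, whether an amine or fluorine on that aromatic carbon would keep the lower number stays open. So does the outcome of hydroxy and vinyl together in one compound.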